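A few compounds are considered here, and "the series" means these few. Any claim that something is new, unique, unknown or untested is made for them only; others in the source may bear on it.

Measured in a functional assay on HL-60 cells (Homo sapiens) for antiproliferative activity; a higher number here means a weaker inhibitor, a lower number a stronger inhibitor:
- compound 1 `COc1ccc(-c2snnc2-c2cc(OC)c(OC)c(OC)c2)cc1O`: 1.5 nM
- compound 2 `COc1ccc(-c2snnc2-c2cc(OC)c(OC)c(OC)c2)cc1[N+](=O)[O-]`: 13.4 nM

Compound 2 has the higher number of the two, so it is the weaker inhibitor in this assay. The next compound, compound 3 `COc1ccc(-c2snnc2-c2cc(OC)c(OC)c(OC)c2)cc1OC`, has methoxy in place of nitro on an aromatic carbon, ortho to a methoxy group: methoxy in place of nitro on an aromatic carbon.

Among the compounds with values here, only one measured step involves this same aromatic carbon: an 8.9-fold higher number from compound 1 to compound 2 (0.95 log units; beyond the scatter). This modest step replaced hydroxy with nitro, so it does not directly compare nitro with methoxy. Compound 3 also lacks the hydroxy of compound 1, so the number for compound 3 is expected to lie closer to that of compound 2 at 13.4 nM than to that of compound 1 at 1.5 nM. With no direct comparison available, only a small rise is expected, and no clear step beyond the scatter: a 1.5-fold higher number from compound 2 to compound 3 (0.17 log units; within the scatter). The estimate for compound 3 is 20 nM, with an expected range of 4 nM to 120 nM.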

Compound 3, half-maximal inhibitory concentration: 60.9 nM
Compound 3: middle estimate off by 3.0-fold (0.48 log units), on the low side, within the range that was stated.
By their numbers in this assay, from the lowest: compound 1; then compound 2; then compound 3.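

In this assay, this aromatic carbon now has three groups that can be compared, and methoxy gives the weakest inhibitor of the three, with a 4.5-fold higher number from compound 2 to compound 3 (0.66 log units; beyond the scatter), so nitro is better tolerated here than methoxy. The sharper lesson comes from the smallest structural change. Adding only a methyl to the oxygen of the hydroxy group gives a 41-fold higher number from compound 1 to compound 3 (1.61 log units; beyond the scatter), which shows that a large loss of activity in this series can come from capping that one oxygen. Across these three compounds the order at this carbon runs from hydroxy through nitro to methoxy, but nothing measured here accounts for that order.

On these data alone, it remains open whether the hydrogen on the oxygen is what matters most, or whether a different group could match hydroxy, such as an amine, a fluorine atom or a plain hydrogen on the same carbon. A longer chain on the oxygen, such as ethoxy, would also show whether activity keeps falling as the group on that oxygen grows beyond methyl.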